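Replacing the 1-methyl-1H-indol-6-yl group of compound 3

The source may report more compounds than this note shows. Statements on the series, on what has been measured and on what is new or still open speak of the compounds shown alone.

In a functional assay on B16-F0 cells (Mus musculus) for inhibition, read by CCK-8 assay, with a stated time of 48 h (a lower number here means a stronger inhibitor, a higher number a weaker inhibitor), compound 1 `COc1cc(-c2ccnc3cc(-c4cn(C)c5ccccc45)nn23)cc(OC)c1OC` gives 185 nM, compound 3 `COc1cc(-c2ccnc3cc(-c4ccc5ccn(C)c5c4)nn23)cc(OC)c1OC` gives 657 nM and compound 2 `COc1cc(-c2ccnc3cc(-c4ccc(C(C)=O)cc4)nn23)cc(OC)c1OC` gives 3930 nM. Compound 3 thus stands in the middle of the three. Compound 4 `COc1ccc(-c2cc3nccc(-c4cc(OC)c(OC)c(OC)c4)n3n2)cc1N` differs from it as follows: 3-amino-4-methoxyphenyl in place of 1-methyl-1H-indol-6-yl on an aromatic carbon. A 3-amino-4-methoxyphenyl group takes the place of 1-methyl-1H-indol-6-yl on an aromatic carbon of the five-membered aromatic ring.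

Three measured steps change the group at this same place. They are modest in a 3.6-fold higher number from compound 1 to compound 3 (0.55 log units; beyond the scatter) and a 6.0-fold lower number from compound 2 to compound 3 (0.78 log units; beyond the scatter), and large in a 21-fold higher number from compound 1 to compound 2 (1.33 log units; beyond the scatter). All lie beyond the scatter, so a step beyond the scatter is expected here too. Among the compounds with values here, no measured compound carries the entering group, so the data do not fix the direction. The entering group shares only a six-membered carbon ring with the 4-acetylphenyl of compound 2, and a tentative lean towards a lower number is taken.

For compound 4 the expected change is modest, a 2.3-fold lower number from compound 3 to compound 4 (0.37 log units; beyond the scatter). Compound 4 is estimated at 280 nM, with an expected range from 45 nM to 1700 nM.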

Compound 4, half-maximal inhibitory concentration: 88 nM
Compound 4: the middle estimate sits 3.2-fold (0.50 log units) above what was measured; the range from low to high includes it.
By their numbers in this assay, from the lowest: compound 4; then compound 1; then compound 3; then compound 2.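

In this assay the two 1-methylindolyl compounds had lower numbers than compound 2, which could be read as favouring a fused group at this place on the five-membered aromatic ring. Compound 4 goes against that reading, as its 3-amino-4-methoxyphenyl group has a single six-membered carbon ring yet gives a 7.5-fold lower number from compound 3 to compound 4 (0.87 log units; beyond the scatter) and a 2.1-fold lower number from compound 1 to compound 4 (0.32 log units; beyond the scatter) and so the lowest number of the four. The two single-ring groups also lie far apart, with a 45-fold lower number from compound 2 to compound 4 (1.65 log units; beyond the scatter) showing that a six-membered carbon ring alone does not set the value, and no evidence is available to explain the gap.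

The compounds shown leave open whether the amino or the methoxy group of compound 4 accounts for this step. They also leave open how a hydroxyl or a carboxylic acid in place of that amino group would read in this assay.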